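Sulfanyl chain variation on the shared core

A few compounds are considered here, and "the series" means these few. Any claim that something is new, unique, unknown or untested is made for them only; others in the source may bear on it.

Compound 1 `CC(C)c1n[nH]c2c(NCc3ccc(-c4ccccn4)cc3)nc(SCC(O)C(F)(F)F)nc12` carries the 2,2,2-trifluoro-1-hydroxyethyl group on a saturated chain carbon bound to a sulfur. In a functional assay on HT cells (Homo sapiens) for antiproliferative activity, read by fluorescence, with a stated time of 72 h (a lower number here means a stronger inhibitor of growth, a higher number a weaker inhibitor of growth), compound 1 gives 690 nM, the highest of the two numbers seen so far. Compound 2 `CC(C)c1n[nH]c2c(NCc3ccc(-c4ccccn4)cc3)nc(SCCNC(N)=O)nc12` differs from it only in that chain; in this assay compound 2 gives 240 nM. Among the measured compounds shown here, the single step recorded between measured compounds is a 2.9-fold lower number from compound 1 to compound 2 (0.46 log units; beyond the scatter).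

Compound 3 `CNCCSc1nc(NCc2ccc(-c3ccccn3)cc2)c2[nH]nc(C(C)C)c2n1` changes the same position once more: (methylamino)methyl in place of 2,2,2-trifluoro-1-hydroxyethyl on a saturated chain carbon bound to a sulfur. For the measured compounds named here, the only step that bears on this change is the one from compound 1 to compound 2, and it concerned a different entering group, so it serves as a guide only for the direction and rough size. Replacing the 2,2,2-trifluoro-1-hydroxyethyl group with a shorter chain has so far moved the number down by a modest amount, and a comparable move is expected here. For compound 3 the expected step in this assay is a 2.3-fold lower number from compound 1 to compound 3 (0.36 log units; beyond the scatter). Going by the values given here, compound 3 is therefore estimated at 300 nM, with a range from 120 nM to 900 nM; the range is wide since the entering group has no measured precedent.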

Compound 3, concentration for 50% growth inhibition: 56 nM
Compound 3: the middle estimate sits 5.4-fold (0.73 log units) above what was measured; the whole stated range lies above it.
By their numbers in this assay, from the lowest: compound 3; then compound 2; then compound 1.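

In this assay this position on the saturated chain carbon bound to a sulfur proves more responsive than the first step indicated: (methylamino)methyl in place of 2,2,2-trifluoro-1-hydroxyethyl gives a 12-fold lower number from compound 1 to compound 3 (1.09 log units; beyond the scatter), a large step, and compound 3 has the lowest number of the three. The result also shows that an amine nitrogen in the chain is not enough to set the number, as compound 2 and compound 3 both carry one, yet methyl in place of carbamoyl on that nitrogen gives a 4.3-fold lower number from compound 2 to compound 3 (0.63 log units; beyond the scatter), so the group on the nitrogen matters in this assay. No measurement at hand explains either step.

The compounds shown leave open whether the methyl on the nitrogen contributes to the lower number, which a 2-aminoethyl or a 2-(dimethylamino)ethyl chain on the sulfur would test directly. Also open, from the compounds shown here alone, is how the number responds to a longer chain ending in the same methylamino group, or to a carboxylic acid at the chain end in place of the amine.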